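A few compounds are considered here, and "the series" means these few. Any claim that something is new, unique, unknown or untested is made for them only; others in the source may bear on it.

Within the data shown here, in a functional assay on HeLa cells (Homo sapiens) for antiproliferative activity, read by MTT assay, with a stated time of 72 h (a lower number here means a stronger inhibitor, a higher number a weaker inhibitor), three related compounds have numbers so far. Compound 1 `CCNC(=O)c1cc(Oc2ccc(NC(=O)c3nn(-c4ccccc4C)c(=O)cc3C)cc2)ccn1` gives 27300 nM, compound 2 `CCNC(=O)c1cc(Oc2ccc(NC(=O)c3nn(-c4ccc(C)cc4)c(=O)cc3C)cc2)ccn1` gives 10700 nM, and compound 3 `CCCNC(=O)c1cc(Oc2ccc(NC(=O)c3nn(-c4ccccc4C)c(=O)cc3C)cc2F)ccn1` gives 24600 nM. Compound 3 therefore lies within the usual scatter of compound 1, while compound 2 has the lowest number of the three, which marks it as the strongest inhibitor here.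

Compound 4 `CCCNC(=O)c1cc(Oc2ccc(NC(=O)c3nn(-c4cccc(F)c4)c(=O)cc3C)cc2F)ccn1` differs from compound 3 in one place, with 3-fluorophenyl in place of 2-methylphenyl on an aromatic nitrogen. Among the measured compounds shown here, only one measured step changes this same group: a 2.6-fold lower number from compound 1 to compound 2 (0.41 log units; beyond the scatter), a modest move beyond the scatter, where 4-methylphenyl replaces 2-methylphenyl. That step also removes the 2-methylphenyl group, but it brings in no fluorine, so it is only a rough guide. Going by that single step, a modest move towards a lower number is expected in this assay, though one lost in the scatter remains possible. The expected step is a 1.8-fold lower number from compound 3 to compound 4 (0.24 log units; within the scatter). For compound 4 the estimated value is 14000 nM, with an expected range from 6000 nM to 30000 nM.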

Compound 4, half-maximal inhibitory concentration: 6660 nM
The estimate for compound 4 lay 2.1-fold (0.32 log units) above the measured number; low and high end bracket the measured number.
By their numbers in this assay, from the lowest: compounds 4 and 2 (each within the scatter of the next); then compounds 3 and 1 (each within the scatter of the next).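

In this assay, the swap from 2-methylphenyl to 3-fluorophenyl on the aromatic nitrogen gives a 3.7-fold lower number from compound 3 to compound 4 (0.57 log units; beyond the scatter). Together with a 2.6-fold lower number from compound 1 to compound 2 (0.41 log units; beyond the scatter), this makes two pairs, on different backgrounds, in which losing 2-methylphenyl at this position goes with a lower number, and the second pair shows that the replacing group can carry a fluorine instead of a methyl. Nothing available here accounts for this change in terms of a measured property or mechanism.

This single swap removes a methyl group, adds a fluorine and shifts the substituent's place on the ring all at once, so the share of each cannot be separated. Plain phenyl, 3-methylphenyl and 2-fluorophenyl on the core of compound 3 would be the comparisons that pull these apart.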